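Removing a Chloro from the Core of Compound 1

The compounds below may be only part of what the source reports. "The series", "measured", "known", "first", "only" and "open" are said of these compounds alone.

Compound 1 `ClCc1ccc(Cn2cnc3nc(Cl)nc(Cl)c32)cc1` — in a functional assay on HT-29 cells (Homo sapiens) for cytotoxicity, read by sulforhodamine B assay, with a stated time of 48 h (a higher number here means that more compound is tolerated, a lower number that less compound is tolerated), compound 1 gives > 100000 nM, a limit of the assay.
Compound 2 `ClCc1cccc(Cn2cnc3c(Cl)nc(Cl)nc32)c1` — in this assay compound 2 gives > 100000 nM, also a limit.
Compound 3 `Nc1nc(Cl)c2ncn(Cc3cccc(CCl)c3)c2n1` — in this assay compound 3 gives 64600 nM.

Compound 1 therefore stands at the limit of > 100000 nM in this assay, at which 2 of the 3 values shown sit, so no number is known for it. The change to compound 4 `ClCc1ccc(Cn2cnc3ncnc(Cl)c32)cc1` is hydrogen in place of chloro on an aromatic carbon. Within the data shown here, the only measured step, an at least 1.5-fold lower number from compound 2 to compound 3 (0.18 log units; that floor lies within the scatter), concerns amino in place of chloro rather than hydrogen, and its size lies within the scatter, so it gives little guidance. Starting from a limit, no shift beyond the scatter can be foreseen. Compound 4 is thus expected to give about 100000 nM, between 30000 nM and 300000 nM, most likely again reported as a limit. The estimated step is a number no higher from compound 1 to compound 4 (the limit leaves the size open).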

Compound 4, concentration lethal to 50% of the cells: 56200 nM
For compound 4 the middle estimate is 1.8-fold (0.25 log units) above the measured one, and the stated range covers the measured number.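

Hydrogen in place of chloro on this aromatic carbon, between two ring nitrogen atoms, gives an at least 1.7-fold lower number from compound 1 to compound 4 (0.25 log units; that floor lies within the scatter) in this assay and so yields a measured number where compound 1 showed only a limit. Among these compounds, this is the first step read for hydrogen at this position, and only its floor is known. Its true size stays unknown, as compound 1 has no number of its own: the limit of > 100000 nM in this assay, at which 2 of the 4 values shown sit.

On these data alone, whether a methyl or a methoxy group on the same carbon would also give a number remains open. So does the part played by the remaining chloro group of compound 4.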